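Chloro in Place of Fluoro: Compound 1 to Compound 4

The compounds below may be only part of what the source reports. "The series", "measured", "known", "first", "only" and "open" are said of these compounds alone.

Measured in a functional assay on FM3A cells (Mus musculus) for cytotoxicity, read by cell counting, with a stated time of 2 days; on this read-out higher numbers stand for weaker inhibition and lower numbers for stronger inhibition:
Compound 1, `Nc1cccc(/C=C2\SC(=O)N(Cc3cccc(F)c3)C2=O)c1`: > 250000 nM, a limit of the assay
Compound 2, `Nc1ccc(/C=C2\SC(=O)N(Cc3cccc(F)c3)C2=O)cc1`: 121000 nM
Compound 3, `CCN1C(=O)S/C(=C\c2ccc(N)cc2)C1=O`: 76000 nM

Compound 1 stands only at a limit, (the limit of > 250000 nM in this assay, at which 1 of the 3 values shown sits), so no number is known for it. The measured steps are an at least 2.0-fold lower number from compound 1 to compound 2 (0.31 log units; beyond the scatter) and a 1.6-fold lower number from compound 2 to compound 3 (0.20 log units; within the scatter); neither touches the halogen on the 3-fluorophenyl. Compound 4, `Nc1cccc(/C=C2\SC(=O)N(Cc3cccc(Cl)c3)C2=O)c1`, differs from compound 1 by chloro in place of fluoro on an aromatic carbon. Among the measured compounds shown here, with no measured step bearing on this change, no step beyond the scatter is expected in this assay, and compound 4 is expected to sit at the limit as well. Compound 4 is therefore estimated at 300000 nM, between 150000 nM and 600000 nM. The expected step is a step that the limit leaves unreadable from compound 1 to compound 4.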

Compound 4, half-maximal inhibitory concentration: 164000 nM
Compound 4: the middle estimate sits 1.8-fold (0.26 log units) above what was measured, and the stated range covers the measured number.
By their numbers in this assay, from the lowest: compounds 3, 2 and 4 (each within the scatter of the next, the first and the last beyond it). At a limit, above all of these: compound 1.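

In this assay, compound 4 puts a measured number on the 3-aminophenyl side, where the only earlier value was a limit, and it is the first compound shown to vary the halogen. The change reads as an at least 1.5-fold lower number from compound 1 to compound 4 (0.18 log units; that floor lies within the scatter), so a real shift from this swap is neither shown nor excluded. Its true size stays unread because compound 1 is held at a limit: the limit of > 250000 nM in this assay, at which 1 of the 4 values shown sits.

Open, from the compounds shown here alone, is how bromo, methyl or methoxy would read on the same aromatic carbon. Also open, going by these compounds, is whether chloro in place of fluoro would move the number for the 4-aminophenyl compound 2, whose value is not a limit.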